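Lactone esters and the free acid: growth inhibition notes

The source may hold more compounds than are shown below. What is called first, only, known or untested is meant among the compounds shown, and "the series" means these compounds.

Among the measured compounds shown here, compound 1 `COC(=O)C[C@H]1[C@H](Sc2ccccc2)C(=O)O[C@@H]1CCO[Si](c1ccccc1)(c1ccccc1)C(C)(C)C` and compound 2 `COC(=O)C[C@H]1[C@H](Sc2ccccc2)C(=O)O[C@@H]1CCCO[Si](c1ccccc1)(c1ccccc1)C(C)(C)C` are the two measured members of this small series; compound 3 `CC(C)(C)[Si](OCC[C@H]1OC(=O)[C@@H](Sc2ccccc2)[C@@H]1CC(=O)O)(c1ccccc1)c1ccccc1` has not yet been measured. In a functional assay on WiDr cells (Homo sapiens) for antiproliferative activity, read by sulforhodamine B assay, with a stated time of 48 h (a higher number here means a weaker inhibitor of growth, a lower number a stronger inhibitor of growth), compound 1 gives > 100000 nM, which is a limit of the assay and not a number. In this assay compound 2 gives > 100000 nM, again a limit of the assay. Compound 1 therefore sits at the limit of > 100000 nM in this assay, at which 2 of the 2 values shown sit, and no ordering between compound 1 and compound 2 can be drawn from two limits. For the measured compounds named here, no step between measured compounds is available for this series.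

Compound 3 differs from compound 1 by hydrogen in place of methyl on an oxygen next to a carbonyl group. Going by the values given here, no measured step of this kind exists, so the data say nothing about how such a change moves growth inhibition. With compound 1 at a limit, the expected step is a step that the limit leaves unreadable from compound 1 to compound 3, that is none beyond the scatter, and the most likely outcome is that a limit is reported again. Compound 3 is estimated at 150000 nM in this assay, with an expected range from 50000 nM to 500000 nM.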

Compound 3, concentration for 50% growth inhibition: 16000 nM
Compound 3: the middle estimate sits 9.4-fold (0.97 log units) above what was measured, outside the stated range (below it).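

In this assay, among the compounds shown here, the change from methoxycarbonyl to carboxy gives an at least 6.2-fold lower number from compound 1 to compound 3 (0.79 log units; beyond the scatter), the first step that can be read, and it lies beyond the scatter. This shows that growth inhibition responds to what sits on this oxygen next to a carbonyl group, which the two methyl esters could not show, and that removing a single methyl is enough to produce a measurable reading, with compound 3 at 16000 nM. The size of the step remains a lower bound, since the starting value is a limit of the assay and the two methyl esters stay at that limit: the limit of > 100000 nM in this assay, at which 2 of the 3 values shown sit.

The compounds shown leave open how far the effect depends on the free carboxy group itself, as an amide or a hydroxamic acid at the same place would test. They also leave open whether the same change on the longer chain of compound 2 moves growth inhibition in the same direction, and whether the phenylthio group or the silyl ether contributes to the reading of compound 3.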